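This account rests on a few compounds, and the source may have more. Where it says the series, first, only, none or still open, it means among the compounds named here.

Measured in an ADME assay on Vero cells (Chlorocebus sabaeus) for cytotoxicity, read by resazurin assay, with a stated time of 3 days; on this read-out higher numbers stand for weaker inhibition and lower numbers for stronger inhibition:

Compound 1 `CCc1ccc(C(=O)Nc2cc3nc(C4CCCCC4)[nH]c3cc2N(CC)CC)cc1`: > 100 ug/mL, a limit of the assay.
Compound 2 `CCN(CC)c1cc2[nH]c(C3CCCCC3)nc2cc1NC(=O)c1ccc(Br)cc1`: > 100 ug/mL, a limit of the assay.
Compound 3 `CCOCCOC(=O)Nc1cc2nc(C3CCCCC3)[nH]c2cc1N(CC)CC`: > 100 ug/mL, a limit of the assay.

Compound 3 stands where the other two stand, at the limit of > 100 ug/mL in this assay, at which 3 of the 3 values shown sit, and none of the three gives a number. The next compound is compound 4 `CCN(CC)c1cc2[nH]c(C3CCCCC3)nc2cc1NC(=O)c1ccc(F)cc1F`, which differs from compound 3 by 2,4-difluorophenyl in place of 2-ethoxyethoxy on a carbonyl carbon. The measured steps that bear on this change are a step that the two limits leave unreadable from compound 1 to compound 2, a step that the two limits leave unreadable from compound 1 to compound 3 and a step that the two limits leave unreadable from compound 2 to compound 3; each swaps the group on the carbonyl carbon or a substituent on the aromatic ring, and none can be sized since both of its ends sit at the limit. Compound 4 is therefore expected to show no step beyond the scatter, a step that the limit leaves unreadable from compound 3 to compound 4. Compound 4 is estimated at 150 ug/mL, range 50 ug/mL to 400 ug/mL, most likely reported again only as a limit.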

Compound 4, half-maximal inhibitory concentration: > 100 ug/mL
Compound 4: only a limit was reported; the forecaster's own chance of this, stated with the estimate: 85%; the middle value lies beyond the limit too.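

No new step can be read between compound 4 and compound 1, compound 2 or compound 3, since each gives only a limit in this assay: the limit of > 100 ug/mL in this assay, at which 4 of the 4 values shown sit.

Going by these compounds, whether any change on the carbonyl carbon shifts this read-out remains open.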